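Styryl phenol cytotoxicity in Jurkat cells: towards compound 4

The source may hold more compounds than are shown below. What is called first, only, known or untested is meant among the compounds shown, and "the series" means these compounds.

Working notes on the series. Compound 1 `C=C[C@@](C)(/C=C/c1ccc(OS(=O)(=O)c2ccc(C)cc2)cc1)CCC=C(C)C` in a functional assay on Jurkat cells (Homo sapiens) for cytotoxicity, with a stated time of 72 h (on this read-out higher numbers stand for an effect only at larger amounts of compound and lower numbers for an effect already at smaller amounts), gives only a limit, > 49000 nM. Compound 2 `C=C[C@@](C)(/C=C/c1ccc(O)cc1)CC/C=C(C)/C=N/N` in this assay likewise gives a limit, > 49000 nM. Compound 3 `C=C[C@@](C)(/C=C/c1ccc(O)c(C=O)c1)CCC=C(C)C` in this assay also stays at a limit, > 49000 nM. Among the measured compounds shown here, compound 3 therefore stands nowhere in particular: all three values shown sit at the limit (the limit of > 49000 nM in this assay, at which 3 of the 3 values shown sit), and no step between measured compounds can be read from them.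

Compound 4 `C=C[C@@](C)(/C=C/c1ccc(O)c(/C=C/c2ccc(Cl)cc2)c1)CCC=C(C)C` is the next member, not yet measured. It differs from compound 3 by 2-(4-chlorophenyl)ethenyl in place of formyl on an aromatic carbon. For the measured compounds named here, with no measured step to lean on, the step from compound 3 to compound 4 is expected to be an at least 1.9-fold lower number from compound 3 to compound 4 (0.29 log units; that floor lies within the scatter), pointing towards an effect at smaller amounts of compound. The estimate for compound 4 in this assay is 25000 nM, with a range from 6000 nM to 60000 nM.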

Compound 4, half-maximal effective concentration: > 49000 nM
Compound 4 ended at the assay's limit (the forecaster's own chance of this, stated with the estimate: 45%); middle value at least 1.9-fold (0.29 log units) from the limit.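

Compound 3 and compound 4 both stay at a limit in this assay, so no step between them can be read: the limit of > 49000 nM in this assay, at which 4 of the 4 values shown sit.

The compounds shown leave open whether any change to the shared core gives a readable value in this assay.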